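The source may hold more compounds than are shown below. What is called first, only, known or untested is meant among the compounds shown, and "the series" means these compounds.

In a functional assay on MCF7 cells (Homo sapiens) for antiproliferative activity, read by MTT assay, with a stated time of 48 h (on this read-out lower numbers stand for stronger inhibition and higher numbers for weaker inhibition), compound 1 (`Cc1ccc2nc(NC(c3cn(-c4ccccc4)nc3-c3cccc(Cl)c3)c3c(O)ccc4ccccc34)sc2c1`) gives 49700 nM and compound 2 (`COc1cccc(-c2nn(-c3ccccc3)cc2C(Nc2nc3ccc(Cl)cc3s2)c2c(O)ccc3ccccc23)c1`) gives 36000 nM. Going by the values given here, these two values lie within the scatter of each other, so compound 2 stands level with the only other measured compound. Compound 3 (`Oc1ccc2ccccc2c1C(Nc1nc2ccc(Cl)cc2s1)c1cn(-c2ccccc2)nc1-c1cccc(Cl)c1`) follows from compound 2 by 3-methoxyphenyl to 3-chlorophenyl: chloro in place of methoxy on an aromatic carbon. Among the compounds with values here, no measured step isolates this change. The 3-chlorophenyl group also occurs in compound 1 at 49700 nM, so no step beyond the scatter is expected in this assay. The expected size is a 1.1-fold higher number from compound 2 to compound 3 (0.02 log units; within the scatter). The estimate for compound 3 is 38000 nM, with an expected range from 15000 nM to 90000 nM.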

Compound 3, half-maximal inhibitory concentration: 17500 nM
Compound 3: middle estimate off by 2.2-fold (0.34 log units), on the high side; the measured number falls inside the stated range.
By their numbers in this assay, from the lowest: compound 3; then compounds 2 and 1 (each within the scatter of the next).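

In this assay, chloro in place of methoxy on an aromatic carbon, meta to a large group, gives a 2.1-fold lower number from compound 2 to compound 3 (0.31 log units; beyond the scatter) as a modest step beyond the scatter. Chloro in place of methyl on an aromatic carbon, at a second place, gives a 2.8-fold lower number from compound 1 to compound 3 (0.45 log units; beyond the scatter) as another modest step, so compound 3, with chloro at both places, has the lowest number of the three. Nothing at hand bears on the reason for either step. As far as these compounds go, whether an amine or a carboxylic acid in place of chloro at either place would lower the number further stays open, as does whether the two places act independently.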